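The source may report more compounds than this note shows. Statements on the series, on what has been measured and on what is new or still open speak of the compounds shown alone.

Working notes on the series. The shared core is that of compound 1 `COc1cc(C2=NN(C(C)=O)C(c3ccc(F)cc3)O2)cc(OC)c1OC`; in a functional assay on PC-3 cells (Homo sapiens) for antiproliferative activity, read by MTT assay, tested at 5 uM (on this read-out lower numbers stand for a weaker effect and higher numbers for a stronger effect at the one concentration tested), compound 1 gives 0.1%. Compound 2 `COc1cc(C2=NN(C(C)=O)C(c3cccc(OC)c3OC)O2)cc(OC)c1OC` differs only in the group on the saturated ring carbon, and in this assay compound 2 gives 58.2%, a change of a number 58.1 percentage points higher from compound 1 to compound 2 (beyond the scatter). Among the compounds with values here, on the two numbers so far compound 2 stands highest, with compound 1 its nearest neighbour and beyond the scatter below it.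

Compound 3 `COc1cc(C2=NN(C(C)=O)C(c3cc(Cl)cc(Cl)c3)O2)cc(OC)c1OC` is not yet measured. The change from compound 2 is 3,5-dichlorophenyl in place of 2,3-dimethoxyphenyl on a saturated ring carbon. Within the data shown here, only one measured step bears on this place, the step from compound 1 to compound 2, and it was large, so the group on this saturated ring carbon evidently moves the read-out strongly. The entering 3,5-dichlorophenyl is, as counted, without the two oxygen atoms and the two hydrogen-bond acceptors of the leaving 2,3-dimethoxyphenyl, so a step downward is expected. A step of a number 38.2 percentage points lower from compound 2 to compound 3 (beyond the scatter) is expected in this assay. Compound 3 is therefore estimated at 20%, between 0% and 50%.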

Compound 3, a percentage reported as inhibition, at one concentration (the size of the read-out at that concentration, not a potency): 93.9%
The estimate for compound 3 lay 73.9 percentage points below the measured number; the measured number lies above the stated range.
By their numbers in this assay, from the lowest: compound 1; then compound 2; then compound 3.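

The group on this saturated ring carbon need not carry oxygen for a high read-out: with 3,5-dichlorophenyl in place of 2,3-dimethoxyphenyl, the change in this assay is a number 35.7 percentage points higher from compound 2 to compound 3 (beyond the scatter), so the two hydrogen-bond acceptors of the leaving group are not required at this place. Chlorine or fluorine on the phenyl ring does not by itself set the level, since 3,5-dichlorophenyl in place of 4-fluorophenyl gives a number 93.8 percentage points higher from compound 1 to compound 3 (beyond the scatter), which places the two halogen-bearing compounds at the two ends of the series, with compound 2 and its methoxy groups in the middle; compound 1 thus goes against any reading that halogen on this ring raises the number. Nothing available accounts for this order.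

The compounds shown leave open whether both chlorine atoms are needed, and how an unsubstituted phenyl, a bromine-bearing phenyl, or a phenyl carrying an amine or a carboxylic acid would read at this place. They also leave open whether the order at the one concentration tested would hold as an order of potency.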